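The source may report more compounds than this note shows. Statements on the series, on what has been measured and on what is new or still open speak of the compounds shown alone.

Of the compounds shown here, three that share one core have so far been measured in an assay on cells for agonist activity at vitamin D3 receptor (Homo sapiens), with a stated time of 96 h; on this read-out higher numbers stand for an effect only at larger amounts of compound and lower numbers for an effect already at smaller amounts. Compound 1 `C#CC(C)OC(=O)c1ccc(C(CC)(CC)c2ccc(OCCC(O)(CC)CC)c(C)c2)n1CC` gives 2650 nM. Compound 2 `CCn1c(C(=O)Nc2cccc(C(F)(F)F)c2)ccc1C(CC)(CC)c1ccc(OCCC(O)(CC)CC)c(C)c1` gives 5900 nM, the highest of the three numbers: its nearest neighbour is compound 1, and the step of a 2.2-fold higher number from compound 1 to compound 2 (0.35 log units; beyond the scatter). Its furthest neighbour is compound 3 `CCOC(=O)CN(C)C(=O)c1ccc(C(CC)(CC)c2ccc(OCCC(O)(CC)CC)c(C)c2)n1CC`, which gives 520 nM. Compound 2 and compound 3 differ only at a carbonyl carbon, and the step of an 11-fold lower number from compound 2 to compound 3 (1.05 log units; beyond the scatter). Compound 4 `CCn1c(C(=O)NC(CC(=O)O)C(=O)OC)ccc1C(CC)(CC)c1ccc(OCCC(O)(CC)CC)c(C)c1` has not yet been measured. It differs from compound 2 at the same amide: a group of 9 heavy atoms (5 carbon, 4 oxygen; no ring) in place of a group of 10 heavy atoms (7 carbon, 3 fluorine; one six-membered aromatic ring of carbon only), on an amide-type nitrogen. Among the compounds with values here, the step that bears most directly on this change is the one from compound 2 to compound 3, where an aromatic group on that amide was likewise replaced by an open chain of carbon and oxygen and the number fell by a large amount; the step of a 5.1-fold lower number from compound 1 to compound 3 (0.71 log units; beyond the scatter) points the same way. The incoming group of compound 4 brings a hydrogen-bond donor that the group entering compound 3 lacks, and nothing measured shows what that does. A lower number than that of compound 2 is therefore expected, by a step of about a 6.6-fold lower number from compound 2 to compound 4 (0.82 log units; beyond the scatter). For compound 4 the estimate is 900 nM, with a range from 250 nM to 3000 nM.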

Compound 4, half-maximal effective concentration: 26 nM
The estimate for compound 4 lay 35-fold (1.54 log units) above the measured number; the measured number lies below the stated range.
By their numbers in this assay, from the lowest: compound 4; then compound 3; then compound 1; then compound 2.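

In this assay, within the data shown here, the number can move much further at this position than the earlier compounds showed: an 11-fold lower number from compound 2 to compound 3 (1.05 log units; beyond the scatter) was the largest step among them, while the group entering compound 4 brings a 230-fold lower number from compound 2 to compound 4 (2.36 log units; beyond the scatter) on the same amide-type nitrogen. Having no ring is not enough by itself: a 20-fold lower number from compound 3 to compound 4 (1.30 log units; beyond the scatter) separates two groups that both lack a ring on this carbonyl carbon. The ester group is also far off, with a 100-fold lower number from compound 1 to compound 4 (2.01 log units; beyond the scatter) at that same carbon, so the low number goes with this particular group and not with any of the earlier ones.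

Nothing measured here says why this group lowers the number so strongly. The entering group carries a carboxylic acid, a methyl ester and the amide hydrogen together, so the compounds shown cannot tell which of these parts matters, and how a primary amide in place of the carboxylic acid would read remains open.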